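Two Sulfur-Bearing Arms on a Saturated Core

A few compounds are considered here, and "the series" means these few. Any claim that something is new, unique, unknown or untested is made for them only; others in the source may bear on it.

Compound 2 `CC(C)S(=O)(=O)CCC12CCC(c3nnc(-c4ccccc4C(F)(F)F)n3C)(CC1)CC2` carries a sulfur-bearing chain on its saturated core. In an assay on CHO-K1 cells for inhibition of 11-beta-hydroxysteroid dehydrogenase type 2 (Mus musculus), read by scintillation proximity assay (a lower number here means a stronger inhibitor, a higher number a weaker inhibitor), compound 2 gives > 4000 nM, which is a limit of the assay and not a measured number. Compound 1 `Cn1c(-c2ccccc2C(F)(F)F)nnc1C12CCC(CCCC(C)(F)F)(CC1)CC2` differs from it only in that chain. In this assay compound 1 gives > 4000 nM, again a limit. For the measured compounds named here, the one measured step is a step that the two limits leave unreadable from compound 1 to compound 2; its size cannot be read because of the limit of > 4000 nM in this assay, at which 2 of the 2 values shown sit. Compound 3 `Cn1c(-c2ccccc2C(F)(F)F)nnc1C12CCC(COc3ccc(S(C)(=O)=O)cc3)(CC1)CC2` is not yet measured; its change from compound 2 is 4-(methylsulfonyl)phenoxy in place of (isopropylsulfonyl)methyl on a saturated chain carbon bound to a saturated ring carbon. Going by the values given here, no measured step reaches a readable number, so nothing here sets an expected direction or size against the scatter. The estimate for compound 3 in this assay is therefore 6000 nM, between 1500 nM and 30000 nM, most likely again only a limit. The step this estimate implies is a step that the limit leaves unreadable from compound 2 to compound 3.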

Compound 3, half-maximal inhibitory concentration: > 4000 nM
Compound 3: a limit, no number; the forecaster's own chance of this, stated with the estimate: 75%; the middle value does not contradict the limit.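

In this assay compound 3 gives > 4000 nM as a limit of the assay and not a number. For the compounds shown here, no step among compound 1, compound 2 and compound 3 can be read: the limit of > 4000 nM in this assay, at which 3 of the 3 values shown sit.

The compounds shown leave open whether any of these three arms on the shared core changes the inhibition, and by how much.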